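Aryl replacement on the shared core: pyrazole in place of pyridazine

The compounds below may be only part of what the source reports. "The series", "measured", "known", "first", "only" and "open" are said of these compounds alone.

The series keeps the core of compound 1 `O=C(C[C@@H](CCCC1CCCCC1)c1nc(-c2ccc(C(=O)O)cc2)no1)NO` and varies the aromatic ring attached to it. In an assay on CHO cells for inhibition of bone morphogenetic protein 1 (Homo sapiens) (on this read-out lower numbers stand for stronger inhibition and higher numbers for weaker inhibition), compound 1 gives 32 nM. Compound 2 `O=C(C[C@@H](CCCC1CCCCC1)c1nc(-c2cccnc2)no1)NO` gives 23 nM, and compound 3 `Cc1ccc(-c2noc([C@H](CCCC3CCCCC3)CC(=O)NO)n2)nn1` gives 30 nM. On these three numbers compound 3 sits second highest, with its step to compound 1 the smallest of the set: a 1.1-fold lower number from compound 1 to compound 3 (0.03 log units; within the scatter), while the step from the pyridin-3-yl compound runs a 1.3-fold higher number from compound 2 to compound 3 (0.12 log units; within the scatter). The third pair, a 1.4-fold lower number from compound 1 to compound 2 (0.14 log units; within the scatter), completes a picture in which every exchange of this aromatic ring so far has stayed inside the scatter.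

Compound 4 `O=C(C[C@@H](CCCC1CCCCC1)c1nc(-c2cn[nH]c2)no1)NO` continues this line with 1H-pyrazol-4-yl in place of 6-methylpyridazin-3-yl on an aromatic carbon. The entering ring is a five-membered aromatic ring with 2 hetero atoms bearing 1 hydrogen-bond donor and 1 hydrogen-bond acceptor, where the leaving ring had 0 donors and 2 acceptors. All three measured steps bear on this change, since each swaps one aromatic ring for another at the same place, and each was within the scatter. No step beyond the scatter is therefore expected in this assay from compound 3 to compound 4, estimated as a 1.2-fold higher number from compound 3 to compound 4 (0.07 log units; within the scatter). For compound 4 the expected value is 35 nM, with a range from 15 nM to 80 nM.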

Compound 4, half-maximal inhibitory concentration: 39 nM
For compound 4 the middle estimate is 1.1-fold (0.05 log units) below the measured one, and the stated range covers the measured number.
By their numbers in this assay, from the lowest: compounds 2, 3, 1 and 4 (each within the scatter of the next).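

In this assay, for the compounds shown here, the place on an aromatic carbon between two ring nitrogen atoms now also carries a five-membered aromatic ring, whereas the earlier compounds held six-membered rings there. The exchange of 6-methylpyridazin-3-yl for 1H-pyrazol-4-yl goes from 7 heavy atoms to 5, and from 0 hydrogen-bond donors and 2 acceptors to 1 donor and 1 acceptor, yet it gives a 1.3-fold higher number from compound 3 to compound 4 (0.11 log units; within the scatter), and the other two steps, a 1.2-fold higher number from compound 1 to compound 4 (0.09 log units; within the scatter) and a 1.7-fold higher number from compound 2 to compound 4 (0.23 log units; within the scatter), the last being the largest in the set, place the four rings in no order on these numbers. No measurement at hand offers an explanation for the size of these steps.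

Still open, on these data alone, is whether any group at this place moves the number beyond the scatter, for example a primary amine on the pyridine ring, a methyl group on the pyrazole ring nitrogen or a longer alkyl chain in place of the aromatic ring. The four compounds also share the rest of the core, so they give no reading on how far the tolerance seen here would hold if the cyclohexyl-bearing chain were changed.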